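Lengthening the ether side chain in a stilbene series

This account rests on a few compounds, and the source may have more. Where it says the series, first, only, none or still open, it means among the compounds named here.

Measured so far:
compound 1 `C=CCOc1cc(/C=C\c2cc(OC)c(OC)c(OC)c2)ccc1OC`: 43500 nM
compound 2 `C/C=C/COc1cc(/C=C\c2cc(OC)c(OC)c(OC)c2)ccc1OC`: 135000 nM
compound 3 `COc1ccc(COc2cc(/C=C\c3cc(OC)c(OC)c(OC)c3)ccc2OC)cc1`: 64000 nM

All three share one core and differ only in the group on a saturated chain carbon bound to an oxygen on an aromatic ring. In an ADME assay on HEK293 cells (Homo sapiens) for inhibition, read by MTT assay, with a stated time of 3 days (a lower number here means a stronger inhibitor, a higher number a weaker inhibitor), compound 3 sits close to compound 1, since the step of a 1.5-fold higher number from compound 1 to compound 3 (0.17 log units; within the scatter) lies within the scatter, while the step of a 2.1-fold lower number from compound 2 to compound 3 (0.32 log units; beyond the scatter) is beyond it, so compound 3 gives a clearly lower number than compound 2.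

Compound 4 `COc1ccccc1/C=C/CCCOc1cc(/C=C\c2cc(OC)c(OC)c(OC)c2)ccc1OC` carries a longer group at the same place: 4-(2-methoxyphenyl)but-3-en-1-yl in place of 4-methoxyphenyl on a saturated chain carbon bound to an oxygen on an aromatic ring. The step that bears most on this is a 3.1-fold higher number from compound 1 to compound 2 (0.49 log units; beyond the scatter), where a longer alkenyl group gave a modestly higher number, and a 1.5-fold higher number from compound 1 to compound 3 (0.17 log units; within the scatter), where an aryl group changed little. Compound 4 is therefore expected to give a modestly higher number, a 1.7-fold higher number from compound 3 to compound 4 (0.24 log units; within the scatter), in this assay. The estimate for compound 4 is 110000 nM, with a range from 45000 nM to 270000 nM.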

Compound 4, half-maximal inhibitory concentration: > 400000 nM
Compound 4 gave a limit, no number; the forecaster's own chance of this, stated with the estimate: 15%; at least 3.6-fold (0.56 log units) between middle value and limit.
By their numbers in this assay, from the lowest: compounds 1 and 3 (each within the scatter of the next); then compound 2. At a limit, above all of these: compound 4.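

In this assay, compound 4 gives a limit, not a number: the limit of > 400000 nM in this assay, at which 1 of the 4 values shown sits. Its steps can therefore be read only as minimum sizes: an at least 6.2-fold higher number from compound 3 to compound 4 (0.79 log units; beyond the scatter), an at least 2.9-fold higher number from compound 2 to compound 4 (0.47 log units; beyond the scatter) and an at least 9.1-fold higher number from compound 1 to compound 4 (0.96 log units; beyond the scatter). Among the compounds shown here, this position therefore does not accept every larger group alike: the aromatic ring of compound 3 left the number within the scatter of compound 1, whereas 4-(2-methoxyphenyl)but-3-en-1-yl, which carries an aromatic ring and a double bond on a longer chain, gives a larger rise than any step among the earlier compounds.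

The compounds shown do not separate the contributions of chain length, the double bond and the ring in this group. A saturated butyl chain, or a chain of the same length ending in an amine or a carboxylic acid, would help to tell these apart.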